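Chloropyridinyl amide in place of trifluoromethylphenyl amide

A few compounds are considered here, and "the series" means these few. Any claim that something is new, unique, unknown or untested is made for them only; others in the source may bear on it.

Compound 1 `O=C(Nc1cccc(-c2oc3cc(-c4ccc(F)cc4)ccc3c(=O)c2O)c1)c1ccc(Cl)cc1` gives 4730 nM in a functional assay on MCF7 cells (Homo sapiens) for antiproliferative activity, read by CCK-8 assay, with a stated time of 72 h; a lower number here means a stronger inhibitor, a higher number a weaker inhibitor.
Compound 2 `O=C(Nc1cccc(-c2oc3cc(-c4ccc(F)cc4)ccc3c(=O)c2O)c1)c1ccc(C(F)(F)F)cc1` gives 32600 nM in this assay.

For the measured compounds named here, compound 2 stands at the higher of the two numbers measured so far, the nearest being compound 1, with a 6.9-fold higher number from compound 1 to compound 2 (0.84 log units; beyond the scatter). Compound 3 `O=C(Nc1cccc(-c2oc3cc(-c4ccc(F)cc4)ccc3c(=O)c2O)c1)c1ccc(Cl)nc1` differs from compound 2 at the carbonyl carbon: 6-chloropyridin-3-yl in place of 4-(trifluoromethyl)phenyl on a carbonyl carbon. Going by the values given here, the only measured step bears on this only in part, since it swaps trifluoromethyl for chloro on the phenyl ring, whereas here a chloro-bearing pyridinyl ring enters. Compound 3 is therefore expected to return toward the number of compound 1, with an estimated 5.0-fold lower number from compound 2 to compound 3 (0.70 log units; beyond the scatter) in this assay. Compound 3 is expected at about 6500 nM, within the range 2000 nM to 22000 nM.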

Compound 3, half-maximal inhibitory concentration: 2890 nM
Beside the measured number, compound 3's estimate is 2.2-fold (0.35 log units) above it, and the stated range covers the measured number.
By their numbers in this assay, from the lowest: compounds 3 and 1 (each within the scatter of the next); then compound 2.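

In this assay the change to 6-chloropyridin-3-yl gives an 11-fold lower number from compound 2 to compound 3 (1.05 log units; beyond the scatter) and so reverses the loss seen with trifluoromethyl, while a 1.6-fold lower number from compound 1 to compound 3 (0.21 log units; within the scatter) shows that, on this carbonyl carbon, the ring nitrogen leaves the number within the scatter of the 4-chlorophenyl amide. Both chloro-bearing rings thus stand apart from the 4-(trifluoromethyl)phenyl amide of compound 2. Nothing shown here accounts for this difference. Still open, on these data alone, is how an amine or a methoxy group in place of the chloro would read on this ring, and whether a pyridinyl ring carrying trifluoromethyl would follow compound 2 or compound 3.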